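Series notes: the substituent on the saturated ring carbon

The source may report more compounds than this note shows. Statements on the series, on what has been measured and on what is new or still open speak of the compounds shown alone.

Measured so far in a functional assay on OVCAR-8 cells (Homo sapiens) for antiproliferative activity, with a stated time of 48 h; on this read-out lower numbers stand for stronger inhibition of growth and higher numbers for weaker inhibition of growth:
compound 1 `Cc1cc(O)c(C2=NN(c3ccc(S(N)(=O)=O)cc3)C(c3ccccc3O)C2)cc1Cl`: 3890 nM
compound 2 `Cc1cc(O)c(C2=NN(c3ccc(S(N)(=O)=O)cc3)C(/C=C/c3ccccc3)C2)cc1Cl`: 3030 nM

Compound 2 gives the lower of the two numbers, but a 1.3-fold lower number from compound 1 to compound 2 (0.11 log units; within the scatter) lies within the scatter, so compound 1 and compound 2 are not separated on this read-out. Compound 3 `COc1ccc(C2CC(c3cc(Cl)c(C)cc3O)=NN2c2ccc(S(N)(=O)=O)cc2)cc1OC` is not yet measured. It differs from compound 2 at the same position that was changed between compound 1 and compound 2: 3,4-dimethoxyphenyl in place of 2-phenylethenyl on a saturated ring carbon. Within the data shown here, the only step that bears on this position is a 1.3-fold lower number from compound 1 to compound 2 (0.11 log units; within the scatter), and it did not reach beyond the scatter; nothing is known about the effect of the two methoxy groups, since no measured pair differs in them. The expectation is therefore a step of no more than scatter size, a 1.1-fold higher number from compound 2 to compound 3 (0.04 log units; within the scatter). For compound 3 in this assay the estimate is 3300 nM, with a range from 1500 nM to 7500 nM.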

Compound 3, concentration for 50% growth inhibition: 3390 nM
Estimate against measurement, compound 3: 1.0-fold (0.01 log units) below, and the stated range covers the measured number.
By their numbers in this assay, from the lowest: compounds 2, 3 and 1 (each within the scatter of the next).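

In this assay, 3,4-dimethoxyphenyl on the saturated ring carbon gives a 1.1-fold higher number from compound 2 to compound 3 (0.05 log units; within the scatter) and a 1.1-fold lower number from compound 1 to compound 3 (0.06 log units; within the scatter), so all three compounds now stand within the scatter of one another. Where the earlier compounds offered a single comparison at this position, there are now three groups, 2-hydroxyphenyl, 2-phenylethenyl and 3,4-dimethoxyphenyl, that this read-out does not separate, and the two methoxy groups bring no step beyond the scatter. No evidence is available that would account for this result.

From the compounds shown here alone, whether an amine, a carboxylic acid or a longer alkyl chain on this carbon would move the number beyond the scatter remains open. The 4-sulfamoylphenyl and 5-chloro-2-hydroxy-4-methylphenyl groups are the same in all three compounds, so the effect of changes at those places is also unknown.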